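The source may report more compounds than this note shows. Statements on the series, on what has been measured and on what is new or still open speak of the compounds shown alone.

Compound 1 `C/C(=C\CC/C(C)=C/CC[C@@H]1[C@@]2(C)CCC(=O)C(C)(C)[C@H]2CC[C@@]1(C)O)CC/C=C(\C)C(=O)OCc1cn(-c2ccccc2Cl)nn1` gives > 150000 nM in a functional assay on DU-145 cells (Homo sapiens) for antiproliferative activity, read by MTT assay, with a stated time of 48 h (a higher number here means a weaker inhibitor, a lower number a stronger inhibitor), which is a limit of the assay.
Compound 2 `C/C(=C\CC/C(C)=C/CC[C@@H]1[C@@]2(C)CCC(=O)C(C)(C)[C@H]2CC[C@@]1(C)O)CC/C=C(\C)C(=O)OCc1cn(-c2ccccc2C)nn1` gives > 150000 nM in this assay, again only a limit.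
Compound 3 `C/C(=C\CC/C(C)=C/CC[C@@H]1[C@@]2(C)CCC(=O)C(C)(C)[C@H]2CC[C@@]1(C)O)CC/C=C(\C)C(=O)OCc1cn(-c2ccccc2C(F)(F)F)nn1` gives > 150000 nM in this assay, also a limit.

Compound 2 therefore stands where all three values sit: at the limit of > 150000 nM in this assay, at which 3 of the 3 values shown sit, with no number of its own. Within the data shown here, the measured steps a step that the two limits leave unreadable from compound 1 to compound 2, a step that the two limits leave unreadable from compound 1 to compound 3 and a step that the two limits leave unreadable from compound 2 to compound 3 are unreadable in size, so the series so far shows no readable movement at all among the groups on the aromatic ring.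

Compound 4 `C/C(=C\CC/C(C)=C/CC[C@@H]1[C@@]2(C)CCC(=O)C(C)(C)[C@H]2CC[C@@]1(C)O)CC/C=C(\C)C(=O)OCc1cn(-c2ccccc2)nn1` is the next member; the change from compound 2 is hydrogen in place of methyl on an aromatic carbon. No readable step bears on it, and the three unreadable ones give no direction. The step that the limit leaves unreadable from compound 2 to compound 4 is expected to be none beyond the scatter, most probably another limit. Compound 4 is estimated at 200000 nM in this assay, in a range from 80000 nM to 600000 nM.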

Compound 4, half-maximal inhibitory concentration: 95500 nM
For compound 4 the middle estimate is 2.1-fold (0.32 log units) above the measured one; the measured number falls inside the stated range.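

Compound 4, with hydrogen on the aromatic carbon ortho to a large group, is the first member of the series to give a number in this assay, while the other compounds stay at one limit: the limit of > 150000 nM in this assay, at which 3 of the 4 values shown sit.

Hydrogen in place of the substituent gives an at least 1.5-fold lower number from compound 2 to compound 4 (0.19 log units; that floor lies within the scatter), an at least 1.5-fold lower number from compound 3 to compound 4 (0.19 log units; that floor lies within the scatter) and an at least 1.5-fold lower number from compound 1 to compound 4 (0.19 log units; that floor lies within the scatter). On these data alone, each of these is only a floor, so the full size of the steps stays unknown.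

As far as these compounds go, what a methoxy group or an amine at this carbon would do remains open, as does any order among methyl, chloro and trifluoromethyl.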